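Series notes: 5-bromo-2-methoxyphenyl in place of 3,5-dibromophenyl

This account rests on a few compounds, and the source may have more. Where it says the series, first, only, none or still open, it means among the compounds named here.

The series is followed in an assay for inhibition of HSP60/HSP10 (Homo sapiens), with a stated time of 60 min; on this read-out higher numbers stand for weaker inhibition and lower numbers for stronger inhibition. Compound 1 has the structure `O=C(Nc1ccc(Sc2nc3ccccc3s2)c(Cl)c1)c1cc(Br)cc(Br)c1`. In this assay compound 1 gives > 100000 nM, which is a limit of the assay and not a number. Compound 2, with the structure `O=C(Nc1cccc(Cl)c1)c1cc(Br)cc(Br)c1`, shares the amide and the 3,5-dibromophenyl group but carries a smaller aryl on the nitrogen. In this assay compound 2 gives > 100000 nM, again a limit rather than a number. Thus compound 1 sits where both values so far sit, as noted in the limit of > 100000 nM in this assay, at which 2 of the 2 values shown sit, and no measured step within the series is available to set a scale.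

Compound 3 has the structure `COc1ccc(Br)cc1C(=O)Nc1ccc(Sc2nc3ccccc3s2)c(Cl)c1`. Relative to compound 1 the change is 5-bromo-2-methoxyphenyl in place of 3,5-dibromophenyl on a carbonyl carbon. Nothing in the two limits shows a direction for this change, so no movement beyond the scatter is expected, and the step from compound 1 to compound 3 is estimated as a step that the limit leaves unreadable from compound 1 to compound 3. For compound 3 in this assay the expected value is 120000 nM, with a range from 30000 nM to 500000 nM, and a numerical result is itself uncertain.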

Compound 3, half-maximal inhibitory concentration: > 100000 nM
Compound 3: no number, only a limit; the forecaster's own chance of this, stated with the estimate: 70%; the middle value does not contradict the limit.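

In this assay compound 3 gives > 100000 nM, which is a limit of the assay and not a number. Compound 1 also stands at a limit, so no step can be read between compound 1 and compound 3: the limit of > 100000 nM in this assay, at which 3 of the 3 values shown sit.

The compounds shown leave open which structural change, if any, would give a numerical value in this assay.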